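This account rests on a few compounds, and the source may have more. Where it says the series, first, only, none or still open, it means among the compounds named here.

In a functional assay on HSC-2 cells (Homo sapiens) for cytotoxicity, read by MTT assay, with a stated time of 48 h (a higher number here means that more compound is tolerated, a lower number that less compound is tolerated), compound 1 `Cc1ccc(/C=C2\CN(C(=O)CCSCCS(=O)(=O)O)C/C(=C\c3ccc(C)cc3)C2=O)cc1` gives 126000 nM, while compound 2 `O=C1/C(=C/c2ccc([N+](=O)[O-])cc2)CN(C(=O)CCSCCO)C/C1=C\c1ccc([N+](=O)[O-])cc1` gives 390 nM. Of the two numbers recorded, compound 2 stands lowest, and compound 1 is its nearest neighbour at a higher number, a gap that lies beyond the scatter; the two structures differ in more than one place, so the gap cannot be tied to any single change. Compound 3 `O=C1/C(=C/c2ccc([N+](=O)[O-])cc2)CN(C(=O)CCSCCS(=O)(=O)O)C/C1=C\c1ccc([N+](=O)[O-])cc1` carries sulfo in place of hydroxy on a saturated chain carbon, two bonds along the chain from a sulfur. Going by the values given here, no measured pair isolates this change on this core. Compound 1, which shares the sulfo chain but not the nitro groups, is the only other point, and on that basis the number for compound 3 is expected to rise from that of compound 2 by a 6.4-fold higher number from compound 2 to compound 3 (0.81 log units; beyond the scatter) in this assay, with wide uncertainty. Compound 3 is therefore estimated at 2500 nM, within a range of 400 nM to 30000 nM.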

Compound 3, half-maximal cytotoxic concentration: 4730 nM
Compound 3: middle estimate off by 1.9-fold (0.28 log units), on the low side; the range from low to high includes it.
By their numbers in this assay, from the lowest: compound 2; then compound 3; then compound 1.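

With the rest of compound 2 unchanged, sulfo in place of hydroxy on a saturated chain carbon, two bonds along the chain from a sulfur, gives a large step in this assay: a 12-fold higher number from compound 2 to compound 3 (1.08 log units; beyond the scatter). Going by these compounds alone, this is the first comparison that differs in one place, and it shows that the number in this assay responds to the group at this position, which the gap between compound 1 and compound 2 could not show. Nothing measured here gives a cause for this step.

The compounds shown leave open where other groups at this position, such as a carboxylic acid, an amine or a longer chain ending in sulfo, would fall relative to compound 2 and compound 3. They also leave open whether the same exchange would give a step of similar size on the core of compound 1, which has no hydroxy partner among them.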